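A Methyl on the Linker Carbon of Compound 3

This account rests on a few compounds, and the source may have more. Where it says the series, first, only, none or still open, it means among the compounds named here.

Compound 3 `O=C(O)c1cccc(OCc2ccc(OCc3c(-c4c(Cl)cccc4Cl)noc3C3CC3)nc2C(F)(F)F)c1` gives 62% in a functional assay on HEK293 cells for agonist activity at Bile acid receptor (Homo sapiens); a higher number here means a larger maximal response, a lower number a smaller maximal response. It stands second highest of the three measured compounds, all within the usual scatter of one another: compound 2 `O=C(O)c1ccccc1OCc1ccc(OCc2c(-c3c(Cl)cccc3Cl)noc2C2CC2)nc1C(F)(F)F` gives 63%, and compound 1 `CC(Nc1ccc(C(=O)O)cc1)c1ccc(OCc2c(-c3c(Cl)cccc3Cl)noc2C2CC2)nc1C(F)(F)F` gives 59%. The step of a number 1 percentage points lower from compound 2 to compound 3 (within the scatter) and the step of a number 3 percentage points higher from compound 1 to compound 3 (within the scatter) are both within the scatter.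

Compound 4 `CC(Oc1cccc(C(=O)O)c1)c1ccc(OCc2c(-c3c(Cl)cccc3Cl)noc2C2CC2)nc1C(F)(F)F` differs from compound 3 by methyl in place of hydrogen on a saturated chain carbon bound to an aromatic carbon and an oxygen on an aromatic ring. For the measured compounds named here, no measured step isolates this change; the step of a number 4 percentage points higher from compound 1 to compound 2 (within the scatter) alters more than the methyl alone, so it does not separate its effect. With every measured step within the scatter, no step beyond the scatter is expected in this assay. Compound 4 is therefore estimated at 62%, between 50% and 74%, an expected step of no change at the digits printed from compound 3 to compound 4 (within the scatter).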

Compound 4, largest response reached (reported as efficacy), in percent of the reference or control that the assay uses: 50%
For compound 4 the middle estimate is 12 percentage points above the measured one; low and high end bracket the measured number.
By their numbers in this assay, from the lowest: compounds 4, 1, 3 and 2 (each within the scatter of the next, the first and the last beyond it).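

In this assay, this chain carbon proves sensitive to a single added methyl, the first step shown to pass the scatter: a number 12 percentage points lower from compound 3 to compound 4 (beyond the scatter). The 1-(3-carboxyphenoxy)ethyl group also gives a number 13 percentage points lower from compound 2 to compound 4 (beyond the scatter), whereas swapping the group on the methyl-bearing carbon gives only a number 9 percentage points lower from compound 1 to compound 4 (within the scatter). No measurement shown explains why the methyl lowers the response. Still open, on these data alone, is whether a larger ethyl or a hydroxyl on this carbon would lower the maximal response as well.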